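From methoxy to tert-butyl: notes on compound 3

This account rests on a few compounds, and the source may have more. Where it says the series, first, only, none or still open, it means among the compounds named here.

Of the compounds shown here, three on one shared core have been measured in a functional assay on HT-29 cells (Homo sapiens) for antiproliferative activity, read by MTT assay, with a stated time of 96 h; on this read-out higher numbers stand for weaker inhibition and lower numbers for stronger inhibition. Compound 1 `CCN(CC)c1ccc(N2C(=O)NC3(CSC4=C3C(=O)c3ncccc3C4=O)C2=O)cc1`, with diethylamino, gives 50 nM. Compound 2 `CCCCCc1ccc(N2C(=O)NC3(CSC4=C3C(=O)c3ncccc3C4=O)C2=O)cc1`, with pentyl, gives 250 nM. Compound 3 `COc1ccc(N2C(=O)NC3(CSC4=C3C(=O)c3ncccc3C4=O)C2=O)cc1`, with methoxy, gives 2 nM, the lowest number of the three, and both of its gaps lie beyond the scatter.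

The step under consideration leads to compound 4 `CC(C)(C)c1ccc(N2C(=O)NC3(CSC4=C3C(=O)c3ncccc3C4=O)C2=O)cc1`: tert-butyl in place of methoxy on an aromatic carbon.

Among the compounds with values here, three measured steps bear on this change. Two end at methoxy and are large: a 25-fold lower number from compound 1 to compound 3 (1.40 log units; beyond the scatter) and a 130-fold lower number from compound 2 to compound 3 (2.10 log units; beyond the scatter). In both pairs, the group other than methoxy carries the higher number, and neither pair goes against this. The third step is modest: a 5.0-fold higher number from compound 1 to compound 2 (0.70 log units; beyond the scatter). Pentyl is the only measured replacement made up of carbon alone, as tert-butyl is, so it offers the nearest guide. Within the data shown here, no measured compound carries tert-butyl, so the range stays wide.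

A large move toward a higher number is therefore expected in this assay. The expected change is a 50-fold higher number from compound 3 to compound 4 (1.70 log units; beyond the scatter). For compound 4 the estimated value is 100 nM, with an expected range of 20 nM to 500 nM.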

Compound 4, half-maximal inhibitory concentration: 150 nM
Compound 4: the middle estimate sits 1.5-fold (0.18 log units) below what was measured, and the stated range covers the measured number.
By their numbers in this assay, from the lowest: compound 3; then compound 1; then compounds 4 and 2 (each within the scatter of the next).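

Methoxy now stands apart from all three other groups at this position in this assay, and no compound goes against this: the carbon-only tert-butyl group gives a 75-fold higher number from compound 3 to compound 4 (1.88 log units; beyond the scatter) and so joins pentyl and diethylamino on the higher side. Tert-butyl and pentyl cannot be told apart here, with a 1.7-fold lower number from compound 2 to compound 4 (0.22 log units; within the scatter) inside the scatter, so the two differently shaped carbon-only groups give no ordering of their own, whereas diethylamino remains separate from both, with a 3.0-fold higher number from compound 1 to compound 4 (0.48 log units; beyond the scatter) and a 5.0-fold higher number from compound 1 to compound 2 (0.70 log units; beyond the scatter) both beyond the scatter. The compounds shown reveal a sharp difference between methoxy and the other groups, but no measurement available here explains it.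

As far as these compounds go, it remains open whether the low number of compound 3 extends to close relatives of methoxy, such as ethoxy or hydroxy, or whether a small carbon group such as methyl would fall with tert-butyl and pentyl. All four compounds carry their group at the same place on the aromatic ring, so what happens when methoxy sits elsewhere on that ring, or when a second methoxy is added, is also unresolved.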